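Adding a 4-Chlorophenyl Group to the Smallest Compound

The source may hold more compounds than are shown below. What is called first, only, known or untested is meant among the compounds shown, and "the series" means these compounds.

Compound 3 `C=C(Br)C(=O)Nc1ccc(/C=C2\SC(=O)N(C)C2=O)cc1` gives 870 nM in a functional assay on HeLa cells (Homo sapiens) for cytotoxicity, read by cell counting, with a stated time of 4 days (on this read-out lower numbers stand for stronger inhibition and higher numbers for weaker inhibition), the lowest number among the three measured compounds. Compound 1 `C=C(Br)C(=O)Nc1ccc(/C=C2\SC(=O)N(Cc3cccc(F)c3)C2=O)cc1` gives 5900 nM and compound 2 `C=C(Br)C(=O)Nc1ccc(/C=C2\SC(=O)N(Cc3ccc(C)cc3)C2=O)cc1` gives 8900 nM. Compound 4 `C=C(Br)C(=O)Nc1ccc(/C=C2\SC(=O)N(Cc3ccc(Cl)cc3)C2=O)cc1` differs from compound 3 in a single place: 4-chlorophenyl in place of hydrogen on a saturated chain carbon bound to an amide-type nitrogen in a ring. Two measured steps run in the opposite direction: a 6.8-fold lower number from compound 1 to compound 3 (0.83 log units; beyond the scatter) and a 10-fold lower number from compound 2 to compound 3 (1.01 log units; beyond the scatter). Both show that putting hydrogen in place of 3-fluorophenyl or 4-methylphenyl lowers the number well beyond the scatter, while the step of a 1.5-fold higher number from compound 1 to compound 2 (0.18 log units; within the scatter) shows that exchanging one of these groups for the other changes little. Restoring such a group is therefore expected to raise the number again, an 8.0-fold higher number from compound 3 to compound 4 (0.91 log units; beyond the scatter). Compound 4 is estimated at 7000 nM, with a range from 3000 nM to 16000 nM.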

Compound 4, half-maximal inhibitory concentration: 2300 nM
Estimate against measurement, compound 4: 3.0-fold (0.48 log units) above; the measured number lies below the stated range.
By their numbers in this assay, from the lowest: compound 3; then compound 4; then compounds 1 and 2 (each within the scatter of the next).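

Among these compounds, the aromatic group at this place matters more than the earlier compounds suggested: with chloro in place of methyl on an aromatic carbon there is a 3.9-fold lower number from compound 2 to compound 4 (0.59 log units; beyond the scatter), and exchanging the whole aromatic group gives a 2.6-fold lower number from compound 1 to compound 4 (0.41 log units; beyond the scatter). Even this group still raises the number relative to the plain methyl, with a 2.6-fold higher number from compound 3 to compound 4 (0.42 log units; beyond the scatter). Nothing measured here gives a reason for these differences. From the compounds shown here alone, it remains open how a longer chain, such as propyl, or a benzyl group carrying an amine or a carboxylic acid would behave at this place.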